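The compounds below may be only part of what the source reports. "The series", "measured", "known", "first", "only" and "open" are said of these compounds alone.

Series notes. Compound 1 `COc1ccc(-c2cc(=O)c3c(OC)cc(OC)cc3n2C)cc1` gives 28000 nM in a functional assay on SUP-B15 cells (Homo sapiens) for antiproliferative activity, with a stated time of 72 h; on this read-out higher numbers stand for an effect only at larger amounts of compound and lower numbers for an effect already at smaller amounts. Compound 2 `COc1ccc(-c2cc(=O)c3c(OC)cc(OC)cc3n2S(=O)(=O)c2ccc(Cl)cc2)cc1` returns only a limit of this assay, > 34400 nM. Among the measured compounds shown here, the one measured step, an at least 1.2-fold higher number from compound 1 to compound 2 (0.08 log units; that floor lies within the scatter), brings (4-chlorophenyl)sulfonyl in place of methyl on an aromatic nitrogen. Compound 3 `COc1ccc(-c2cc(=O)c3c(OC)cc(OC)cc3n2S(=O)(=O)Cc2ccccc2)cc1` differs from compound 2 by benzyl in place of 4-chlorophenyl on a sulfonyl sulfur. For the measured compounds named here, no measured step covers this change; the only point of reference is the limit of > 34400 nM in this assay, at which 1 of the 2 values shown sits. Compound 3 is expected to sit near that same limit, the step that the limit leaves unreadable from compound 2 to compound 3 expected to stay within the scatter. Compound 3 is estimated at 40000 nM, between 15000 nM and 120000 nM.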

Compound 3, half-maximal effective concentration: > 34400 nM
Compound 3 ended at the assay's limit; the forecaster's own chance of this, stated with the estimate: 70%; the middle value is on the limit's open side.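

Benzylsulfonyl on the aromatic nitrogen, like (4-chlorophenyl)sulfonyl, ends at a limit in this assay: the limit of > 34400 nM in this assay, at which 2 of the 3 values shown sit.

Measured from the methyl group, the change gives an at least 1.2-fold higher number from compound 1 to compound 3 (0.08 log units; that floor lies within the scatter). Among the compounds shown here, no step between compound 2 and compound 3 can be read, as both values are limits.

Open, going by these compounds, is whether any group on this nitrogen gives a clearly lower number than methyl does in compound 1. A sulfonyl group carrying an amine or a carboxylic acid, or a longer alkyl chain in place of methyl, would address this.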